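The compounds below may be only part of what the source reports. "The series", "measured", "known", "first", "only" and "open" are said of these compounds alone.

Measured so far:
compound 1 `CCOC(=O)c1c(-c2c(Cl)c3ccccc3oc2=O)nn(-c2ccccc2)c1C(=O)OCC` — 100000 nM
compound 2 `CCOC(=O)c1c(-c2c(Cl)c3ccccc3oc2=O)nn(-c2ccc(OC)cc2)c1C(=O)OCC` — 27000 nM
compound 3 `CCOC(=O)c1c(-c2c(Cl)c3ccccc3oc2=O)nn(-c2cccc(Cl)c2)c1C(=O)OCC` — 40000 nM

All three were read in a functional assay on HeLa cells (Homo sapiens) for cytotoxicity, read by MTT assay, with a stated time of 48 h; a lower number here means a stronger inhibitor, a higher number a weaker inhibitor. Compound 3 stands second highest of the three numbers: its nearest neighbour is compound 2, a 1.5-fold higher number from compound 2 to compound 3 (0.17 log units; within the scatter), and its furthest is compound 1, a 2.5-fold lower number from compound 1 to compound 3 (0.40 log units; beyond the scatter). Compound 4 `CCOC(=O)c1c(-c2c(Cl)c3ccccc3oc2=O)nn(-c2ccc(Br)cc2)c1C(=O)OCC` has not yet been measured. Relative to compound 3 the change is 4-bromophenyl in place of 3-chlorophenyl on an aromatic nitrogen. Among the measured compounds shown here, two measured steps bear on it: a 3.7-fold lower number from compound 1 to compound 2 (0.57 log units; beyond the scatter) and a 2.5-fold lower number from compound 1 to compound 3 (0.40 log units; beyond the scatter). Each of the two substituted rings on the aromatic nitrogen gave a modestly lower number than the unsubstituted compound 1, while the two substituted rings themselves differ only within the scatter, a 1.5-fold higher number from compound 2 to compound 3 (0.17 log units; within the scatter). Nothing in the data separates one substituted ring from another, so a third substituted ring is expected to land near the other two, and the step of a 1.3-fold lower number from compound 3 to compound 4 (0.12 log units; within the scatter) is expected to stay within the scatter. Compound 4 is therefore estimated at 30000 nM, with a range of 10000 nM to 100000 nM.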

Compound 4, half-maximal inhibitory concentration: 500000 nM
Estimate against measurement, compound 4: 17-fold (1.22 log units) below; measured number above the stated range.
By their numbers in this assay, from the lowest: compounds 2 and 3 (each within the scatter of the next); then compound 1; then compound 4.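

In this assay, a 5.0-fold higher number from compound 1 to compound 4 (0.70 log units; beyond the scatter) runs opposite to the methoxy and chloro steps from compound 1, so a substituent on this phenyl ring does not in itself lower the number. The ring on the aromatic nitrogen can also separate the compounds sharply: both a 13-fold higher number from compound 3 to compound 4 (1.10 log units; beyond the scatter) and a 19-fold higher number from compound 2 to compound 4 (1.27 log units; beyond the scatter) are large, although the 4-methoxyphenyl and 3-chlorophenyl rings of compounds 2 and 3 stay within the scatter of each other. No measurement on hand offers an explanation for this jump.

Compound 3 and compound 4 differ in both halogen and ring position, so the two contributions remain unseparated; a 4-chlorophenyl ring would bear directly on this. On these data alone, whether a ring carrying an amine or a carboxylic acid would follow compound 2 or compound 4 also remains open.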